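The source may hold more compounds than are shown below. What is called first, only, known or untested is meant among the compounds shown, and "the series" means these compounds.

Measured in a functional assay on L02 cells (Homo sapiens) for cytotoxicity, read by MTT assay, with stated times of 48 h and 4 h; on this read-out higher numbers stand for weaker inhibition and lower numbers for stronger inhibition:
- Compound 1 `COc1ccc(/C=C/c2nc(NCCN3CCCCC3)c3ccccc3n2)cc1OC`: 19800 nM
- Compound 2 `COc1ccc(/C=C/c2nc(NCCCCN)c3ccccc3n2)cc1OC`: > 100000 nM (a limit, not a number)

Going by the values given here, compound 1 holds the only true number so far. Compound 2 sits at a limit of this assay.

Compound 3 `O=[N+]([O-])c1ccc(/C=C/c2nc(NCCN3CCCCC3)c3ccccc3n2)cc1` keeps the rest of compound 1 and changes one group: 4-nitrophenyl in place of 3,4-dimethoxyphenyl on a double-bonded chain carbon bound to a double-bonded chain carbon. Among the compounds with values here, the one measured step, an at least 5.0-fold higher number from compound 1 to compound 2 (0.70 log units; beyond the scatter), lies beyond the scatter, but it alters the side chain and not this group, so it gives no direct guide. Within the data shown here, with no measured step at this place, no change beyond the scatter is expected, and the expected step is a 1.0-fold higher number from compound 1 to compound 3 (0.00 log units; within the scatter). For compound 3 the estimated value is 20000 nM, with an expected range of 7000 nM to 60000 nM.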

Compound 3, half-maximal inhibitory concentration: > 100000 nM
Compound 3: only a limit was reported (the forecaster's own chance of this, stated with the estimate: 10%); middle value at least 5.0-fold (0.69 log units) from the limit.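

The group on a double-bonded chain carbon bound to a double-bonded chain carbon also affects this read-out, not only the side chain: with 4-nitrophenyl in place of 3,4-dimethoxyphenyl, this assay shows an at least 5.0-fold higher number from compound 1 to compound 3 (0.70 log units; beyond the scatter). Compound 3 gives only a limit, so the full size of this step cannot be read: the limit of > 100000 nM in this assay, at which 2 of the 3 values shown sit.

Going by these compounds, whether the step comes from losing the two methoxy groups or from gaining the nitro group stays open. A plain phenyl or a 4-methoxyphenyl group at this place would separate the two.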